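The source may report more compounds than this note shows. Statements on the series, on what has been measured and on what is new or still open speak of the compounds shown alone.

Measured so far:
Compound 1 `COc1ccc(C(=O)/C=C/c2cc(-c3cc(OC)c(OC)c(OC)c3)n[nH]2)cc1OC`: 1480 nM
Compound 2 `COc1ccc(C(=O)/C=C/c2cc(-c3cc(OC)c(OC)c(OC)c3)n[nH]2)cc1`: 1880 nM

In a functional assay on MDA-MB-231 cells (Homo sapiens) for inhibition, read by sulforhodamine B assay, with a stated time of 48 h (a lower number here means a stronger inhibitor of growth, a higher number a weaker inhibitor of growth), compound 1 gives 1480 nM and compound 2 gives 1880 nM. Compound 2 stands at the higher of these two numbers, but the step of a 1.3-fold higher number from compound 1 to compound 2 (0.10 log units; within the scatter) is within the scatter, so the two compounds cannot be told apart on these numbers.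

Compound 3 `COc1cc(-c2cc(/C=C/C(=O)c3ccc(F)c(F)c3)[nH]n2)cc(OC)c1OC` has not yet been measured. It differs from compound 2 by 3,4-difluorophenyl in place of 4-methoxyphenyl on a carbonyl carbon. For the measured compounds named here, the one measured step, a 1.3-fold higher number from compound 1 to compound 2 (0.10 log units; within the scatter), concerns the loss of a single methoxy at a different place and was small; no measured step covers the exchange of the whole aryl group on the carbonyl. Going by the values given here, since the only known change to this part of the molecule was within the scatter, compound 3 is expected to show a step of about a 1.3-fold higher number from compound 2 to compound 3 (0.12 log units; within the scatter), that is, no clear change. Compound 3 is therefore estimated at 2500 nM, with a range from 900 nM to 7000 nM.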

Compound 3, concentration for 50% growth inhibition: 1640 nM
Beside the measured number, compound 3's estimate is 1.5-fold (0.18 log units) above it; measured number inside the range.
By their numbers in this assay, from the lowest: compounds 1, 3 and 2 (each within the scatter of the next).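

In this assay, exchanging the whole aryl group on the carbonyl carbon gives a 1.1-fold lower number from compound 2 to compound 3 (0.06 log units; within the scatter) and also a 1.1-fold higher number from compound 1 to compound 3 (0.04 log units; within the scatter) when compound 1 is the starting point. The earlier step covered the loss of a single methoxy, whereas here no methoxy remains on that ring, and 3,4-difluorophenyl still cannot be told apart from 4-methoxyphenyl or 3,4-dimethoxyphenyl at this position. Nothing available here bears on why these aryl groups read alike.

Open, on these data alone, is whether a group of another kind on that ring, such as an amine or a carboxylic acid, would also read alike, or whether an aromatic ring is needed on the carbonyl carbon at all. These compounds all share the rest of the molecule, so they say nothing about changes to the core.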